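Aryl swap on the thiophene: compound 3 to compound 4

The compounds below may be only part of what the source reports. "The series", "measured", "known", "first", "only" and "open" are said of these compounds alone.

Among the measured compounds shown here, compound 3 `Nc1scc(-c2ccccc2F)c1C(=O)c1ccc(Cl)cc1` gives 87% in a functional assay on CHO cells for agonist activity at adenosine receptor A1 (Homo sapiens), read by fluorescence and ERK phosphorylation, with stated times of 30 min and 1.5 h, tested at 10 uM (a higher number here means a stronger effect of the compound at the concentration tested, a lower number a weaker effect), the highest of the three numbers measured so far; compound 1 `Nc1scc(-c2ccccc2F)c1C(=O)c1ccccc1` gives 68%, and compound 2 `Nc1scc(-c2cccc([N+](=O)[O-])c2)c1C(=O)c1ccccc1` gives 50%, both beyond the scatter below compound 3. For the measured compounds named here, the only measured step, a number 19 percentage points higher from compound 1 to compound 3 (beyond the scatter), concerns the benzoyl side and not the ring changed here. Compound 4 `Nc1scc(-c2ccc(Cl)cc2)c1C(=O)c1ccc(Cl)cc1` differs from compound 3 by 4-chlorophenyl in place of 2-fluorophenyl on an aromatic carbon. Going by the values given here, no measured step covers this change; compound 1 and compound 2 differ in that same aryl group and their values sit apart, so a change there can move the number, but the direction is unknown. The step of a number 9 percentage points lower from compound 3 to compound 4 (within the scatter) is therefore expected to be small. Compound 4 is estimated at 78%, range 58% to 95%.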

Compound 4, a percentage reported as activity, at one concentration (the size of the read-out at that concentration, not a potency): 50%
Estimate against measurement, compound 4: 28 percentage points above, outside the stated range (below it).
By their numbers in this assay, from the lowest: compounds 2 and 4 (each within the scatter of the next); then compound 1; then compound 3.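

Replacing 2-fluorophenyl with 4-chlorophenyl gives a number 37 percentage points lower from compound 3 to compound 4 (beyond the scatter) in this assay, so this aryl position strongly affects the read-out even with the chloro on the benzoyl side kept. Both groups hold the same count of heavy atoms and no hydrogen-bond donors or acceptors, so the drop occurs with those counts unchanged. Nothing available bears on the cause of this drop.

Going by these compounds, whether the halogen or its place on the phenyl governs the step remains open; 2-chlorophenyl or 4-fluorophenyl would separate the two. On these data alone, the effect of an amine or a carboxylic acid on this phenyl also remains open.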